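Swapping a Furan Ring for an Open Chain

The source may hold more compounds than are shown below. What is called first, only, known or untested is meant among the compounds shown, and "the series" means these compounds.

Of the compounds shown here, three have so far been tested in a functional assay on K562 cells (Homo sapiens) for inhibition, read by thymidine incorporation, with a stated time of 48 h, tested at 10 ug/mL; a higher number here means more inhibition at the concentration tested (going by the name of the read-out), a lower number less inhibition. Compound 1 `OC[C@H]1OC(n2cnc3c(C#Cc4ccccc4)ncnc32)[C@H](O)[C@@H]1O` gives 100% in this assay. Compound 2 `C(=C/c1[nH]cnc2ncnc1-2)\c1ccco1` gives 24%, and compound 3 `C(=C/c1ncnc2c1ncn2C1CCOCC1)\c1ccco1` gives 35%. Compound 2 therefore stands lowest of the three numbers: its nearest neighbour is compound 3, whose number is higher by a margin beyond the usual scatter, and compound 1 lies furthest away, also beyond the scatter.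

The change followed here starts from compound 2 and leads to compound 4 `C/C(=C\C=C\c1[nH]cnc2ncnc1-2)CO`, which has not yet been measured. The difference between the two structures is 2-(hydroxymethyl)prop-1-en-1-yl in place of furan-2-yl on a double-bonded chain carbon bound to a double-bonded chain carbon. A five-membered aromatic ring leaves and an open chain carrying a hydrogen-bond donor enters, at the place described: on a double-bonded chain carbon bound to a double-bonded chain carbon.

Going by the values given here, no measured pair in this set differs in exactly this way, so there is no comparable step to lean on. With compound 2 already at the bottom of the measured range and nothing in the data pointing one way or the other, the expected step of a number 4 percentage points lower from compound 2 to compound 4 (within the scatter) is one of no size beyond the scatter. Compound 4 is therefore estimated at 20%, within a range from 5% to 45%.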

Compound 4, a percentage reported as inhibition, at one concentration (the size of the read-out at that concentration, not a potency): 6%
Compound 4: middle estimate off by 14 percentage points, on the high side; low and high end bracket the measured number.
By their numbers in this assay, from the lowest: compound 4; then compound 2; then compound 3; then compound 1.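

In this assay, putting 2-(hydroxymethyl)prop-1-en-1-yl in place of furan-2-yl gives a number 18 percentage points lower from compound 2 to compound 4 (beyond the scatter), a modest step. This shows that the place on a double-bonded chain carbon bound to a double-bonded chain carbon responds to the group it carries, even though both groups hold the same count of heavy atoms, four carbons and one oxygen, so matching atom counts do not keep the read-out level here. No measurement at hand says which feature of the exchange lies behind this step.

The exchange removes a five-membered aromatic ring and adds a hydrogen-bond donor in one move, so the compounds shown cannot separate these two changes; a plain 2-methylprop-1-en-1-yl chain would remove the hydroxyl while keeping the open chain, a thiophene ring would keep a five-membered aromatic ring with a different hetero atom, and an amine in place of the hydroxyl would change the chain's end. Also open, going by these compounds, is whether the same exchange would give a step of similar size on the core of compound 3, where the ring nitrogen carries a substituent.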